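The compounds below may be only part of what the source reports. "The series", "measured", "known", "first", "only" and "open" are said of these compounds alone.

Measured compounds in a functional assay on HT-29 cells (Homo sapiens) for cytotoxicity, read by MTT assay, with a stated time of 72 h; on this read-out lower numbers stand for stronger inhibition of growth and higher numbers for weaker inhibition of growth:
- compound 1 `CCCCC[Se]c1nc([Se]CCCCC)c2ccccc2n1`, giving > 100000 nM, which is a limit of the assay and not a number
- compound 2 `Sc1nc(NCc2ccccc2)c2ccccc2n1`, giving 10100 nM

Within the data shown here, compound 2 stands as the only numeric value in this assay; the other entry is the limit of > 100000 nM in this assay, at which 1 of the 2 values shown sits. Among the measured compounds shown here, no step between measured compounds can be drawn, since compound 1 and compound 2 differ in more than one place and the result for compound 1 is a limit.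

Compound 3 `C[Se]c1nc(NCc2ccccc2)c2ccccc2n1` is not yet measured. It differs from compound 2 by a group of 2 heavy atoms (1 carbon, 1 selenium; no ring) in place of one sulfur atom, on an aromatic carbon. For the measured compounds named here, with no measured step on this change, the expectation rests only on compound 2 and its value 10100 nM. A modest weakening beyond the scatter, or none, is expected for compound 3, as the step of a 1.8-fold higher number from compound 2 to compound 3 (0.25 log units; within the scatter). Compound 3 is estimated at 18000 nM in this assay, with a range from 4000 nM to 70000 nM.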

Compound 3, concentration for 50% growth inhibition: 42800 nM
Beside the measured number, compound 3's estimate is 2.4-fold (0.38 log units) below it; low and high end bracket the measured number.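

In this assay, the aromatic carbon between two ring nitrogen atoms proves sensitive to this change, with a 4.2-fold higher number from compound 2 to compound 3 (0.63 log units; beyond the scatter), and growth inhibition weakens when the group of 2 heavy atoms (1 carbon, 1 selenium) takes the place of the sulfanyl. The entering group counts 0 hydrogen-bond donors and 0 hydrogen-bond acceptors against 1 of each on the sulfanyl, but that count alone does not establish what drives the step. Among these compounds, nothing measured so far bears on the cause of this step.

On these data alone, whether the weakening belongs to the selenium atom or to the added carbon stays open, and a methylthio group in the same place would separate the two, as a longer chain on selenium or an amine would test the reach of the position. Compound 1 carries a limit of the assay, > 100000 nM, and differs from compound 3 in more than one place, so it gives no reading on this position.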